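The source may report more compounds than this note shows. Statements on the series, on what has been measured and on what is new or still open speak of the compounds shown alone.

Working notes on the series. Compound 3 `Cc1cccc(NC(=O)NC2CC(C)(C)Oc3ccc(Cl)cc32)c1` is the point of departure. In a functional assay (aorta) with Rattus norvegicus as the target (a lower number here means that less compound is needed, a higher number that more compound is needed for the effect), compound 3 gives > 10000 nM, which is a limit of the assay and not a number. Compound 1 `COc1ccccc1NC(=O)NC1CC(C)(C)Oc2ccc(Cl)cc21` gives > 10000 nM in this assay, also a limit. Compound 2 `Cc1cccc(NC(=O)NC2CC(C)(C)Oc3ccc(F)cc32)c1` gives > 30000 nM in this assay, again a limit. The two measured steps that lead to compound 3 are a step that the two limits leave unreadable from compound 1 to compound 3 and a step that the two limits leave unreadable from compound 2 to compound 3; both run between limits, so neither yields a size or a direction. Where the values sit is summed up by the limit of > 10000 nM in this assay, at which 2 of the 3 values shown sit, and by the limit of > 30000 nM in this assay, at which 1 of the 3 values shown sits.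

Compound 4 `CC1(C)CC(NC(=O)Nc2ccccc2Cl)c2cc(Cl)ccc2O1` carries the change (2-chlorophenyl in place of 3-methylphenyl on an amide-type nitrogen). The step that bears on it most closely is a step that the two limits leave unreadable from compound 1 to compound 3, in which a differently substituted phenyl sat on the same amide-type nitrogen, and that step is unreadable. Among the measured compounds shown here, no readable step exists for this kind of change; every value measured so far in this assay is a limit. For compound 4 the expectation is a further limit, with the step that the limit leaves unreadable from compound 3 to compound 4 expected to stay within the scatter. Compound 4 is therefore estimated at 20000 nM, with a range from 5000 nM to 100000 nM.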

Compound 4, half-maximal effective concentration: > 300000 nM
Compound 4: a limit, no number; the forecaster's own chance of this, stated with the estimate: 85%; at least 15-fold (1.17 log units) between middle value and limit.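

In this assay compound 4 gives > 300000 nM, which is a limit of the assay and not a number. Its steps from compound 1 and from compound 3 both run between limits, so neither can be read. The compounds shown leave open whether changing the substituted phenyl on the amide-type nitrogen shifts the half-maximal effective concentration at all.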